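Replacing the thiophene on compound 1's carbonyl with a methylated aniline

A few compounds are considered here, and "the series" means these few. Any claim that something is new, unique, unknown or untested is made for them only; others in the source may bear on it.

Compound 1 `COc1ccc(S(=O)(=O)N2CCc3cccc(NC(=O)c4cccs4)c32)cc1` gives the lowest number of the three measured compounds in a functional assay on MKN-45 cells (Homo sapiens) for cytotoxicity (on this read-out lower numbers stand for stronger inhibition and higher numbers for weaker inhibition), at 31 nM. Compound 3 `COc1ccc(S(=O)(=O)N2CCc3cccc(NC(=O)c4ccc(C#N)cc4)c32)cc1` gives 89 nM, and compound 2 `COc1ccc(S(=O)(=O)N2CCc3cccc(NS(=O)(=O)c4ccccc4)c32)cc1` gives 562 nM. Compound 4 `COc1ccc(S(=O)(=O)N2CCc3cccc(NC(=O)N(C)c4ccccc4)c32)cc1` differs from compound 1 in one place: methyl(phenyl)amino in place of thiophen-2-yl on a carbonyl carbon. Among the compounds with values here, two measured steps bear on this. Swapping the group on the carbonyl carbon gave a 2.9-fold higher number from compound 1 to compound 3 (0.46 log units; beyond the scatter), and the larger change at the nitrogen on the aromatic ring gave an 18-fold higher number from compound 1 to compound 2 (1.26 log units; beyond the scatter). Since the change to compound 4 also replaces the group on the carbonyl carbon, a weakening of similar, modest size is expected, a 4.8-fold higher number from compound 1 to compound 4 (0.68 log units; beyond the scatter). Compound 4 is therefore estimated at 150 nM in this assay, within 50 nM to 500 nM.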

Compound 4, half-maximal inhibitory concentration: > 10000 nM
Compound 4: no number, only a limit; the forecaster's own chance of this, stated with the estimate: 5%; middle value at least 66-fold (1.82 log units) from the limit.
By their numbers in this assay, from the lowest: compound 1; then compound 3; then compound 2. At a limit, above all of these: compound 4.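

Compound 4 gives no number in this assay, only a limit: the limit of > 10000 nM in this assay, at which 1 of the 4 values shown sits. So the group on this carbonyl carbon matters far more than the earlier compounds showed: methyl(phenyl)amino brings an at least 320-fold higher number from compound 1 to compound 4 (2.50 log units; beyond the scatter) and, against 4-cyanophenyl, an at least 110-fold higher number from compound 3 to compound 4 (2.05 log units; beyond the scatter). This single change on the carbonyl carbon even outdoes phenylsulfonyl on the nitrogen, the largest earlier loss, with an at least 17-fold higher number from compound 2 to compound 4 (1.25 log units; beyond the scatter).

Still open, from the compounds shown here alone, is whether the loss goes with the methyl or with the nitrogen itself; a phenylamino group on the same carbonyl carbon would separate the two.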